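This account rests on a few compounds, and the source may have more. Where it says the series, first, only, none or still open, it means among the compounds named here.

Measured so far:
- compound 1, `CCCCCCCCCCc1ccc(-c2noc([C@@H]3CCNC3)n2)cc1`: 62%
- compound 2, `CCCCCCCCCCc1ccc(-c2noc([C@H]3CCCN3)n2)cc1`: 12%
- compound 3, `CCCCCCCCCCc1ccc(-c2noc(-c3cccc(CN)c3)n2)cc1`: 2%

In an assay on HeLa cells for inhibition of sphingosine-1-phosphate transporter SPNS2 (Mus musculus), read by LC-MS, tested at 2 uM (on this read-out higher numbers stand for more inhibition at the one concentration tested (going by the name of the read-out) and lower numbers for less inhibition), compound 3 stands lowest of the three numbers; its nearest neighbour is compound 2, separated by a number 10 percentage points lower from compound 2 to compound 3 (within the scatter), and its furthest is compound 1, separated by a number 60 percentage points lower from compound 1 to compound 3 (beyond the scatter). Compound 1 and compound 2 themselves differ by a number 50 percentage points lower from compound 1 to compound 2 (beyond the scatter).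

Compound 4, `CCCCCCCCCCc1ccc(-c2noc(CC[C@@H](N)C(=O)O)n2)cc1`, is not yet measured. It differs from compound 3 in one place: 3-amino-3-carboxypropyl in place of 3-(aminomethyl)phenyl on an aromatic carbon. The two steps that bear on this change are those that lead into compound 3, namely a number 60 percentage points lower from compound 1 to compound 3 (beyond the scatter) and a number 10 percentage points lower from compound 2 to compound 3 (within the scatter): both show that the 3-(aminomethyl)phenyl group in compound 3 sits at the low end of the series, so replacing it leaves room upward. Among the measured compounds shown here, no measured step, however, shows the 3-amino-3-carboxypropyl group entering anywhere, so its effect in this assay is unknown. For the measured compounds named here, the expectation is therefore only that the number for compound 4 is unlikely to fall further than compound 3 and may recover part of the way toward compound 1; a step of about a number 28 percentage points higher from compound 3 to compound 4 (beyond the scatter) is expected. The estimate for compound 4 is 30%, with a range from 5% to 65%.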

Compound 4, a percentage reported as inhibition, at one concentration (the size of the read-out at that concentration, not a potency): 5%
For compound 4 the middle estimate is 25 percentage points above the measured one; the range from low to high includes it.
By their numbers in this assay, from the lowest: compounds 3, 4 and 2 (each within the scatter of the next); then compound 1.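

In this assay, the open-chain 3-amino-3-carboxypropyl group, on an aromatic carbon of the five-membered aromatic ring, gives a number 3 percentage points higher from compound 3 to compound 4 (within the scatter) and a number 7 percentage points lower from compound 2 to compound 4 (within the scatter), so a group with no ring cannot be told apart from the 3-(aminomethyl)phenyl or pyrrolidin-2-yl groups at this place. Among the compounds shown here, with a number 57 percentage points lower from compound 1 to compound 4 (beyond the scatter), pyrrolidin-3-yl remains the only one of the four groups whose number stands clear of the others, and three quite different replacements, one of them carrying both an amine and a carboxylic acid, all share the same low level. No measurement at hand accounts for this difference between pyrrolidin-3-yl and the other groups.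

Still open, going by these compounds, is whether the number of compound 1 depends on the pyrrolidine ring itself, or would hold with an azetidine or a piperidine carrying the amine, or with the opposite stereocentre of pyrrolidin-3-yl. On these data alone, the separate contributions of the amine and the carboxylic acid in compound 4 are also open, and a plain aminoalkyl chain without the carboxylic acid, or a longer chain, would bear on that.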